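Loosening an ester to its acid on the amide tail

The source may report more compounds than this note shows. Statements on the series, on what has been measured and on what is new or still open speak of the compounds shown alone.

Three measured compounds share one core and differ only in the group carried by an amide-type nitrogen. Compound 1 `CCn1c(C(=O)N[C@H](C)C(=O)OC)ccc1C(CC)(CC)c1ccc(OCS(=O)(=O)c2ccccc2)c(C)c1` carries a 1-(methoxycarbonyl)ethyl group there. In a functional assay on PC-3 cells (Homo sapiens) for antiproliferative activity, read by MTT assay, with a stated time of 24 h (a higher number here means a weaker inhibitor, a lower number a stronger inhibitor), compound 1 reaches only a limit, > 50000 nM, so no number is known for it; the limit of > 50000 nM in this assay, at which 1 of the 3 values shown sits, marks that. Compound 2 `CCN(CC)CCNC(=O)c1ccc(C(CC)(CC)c2ccc(OCS(=O)(=O)c3ccccc3)c(C)c2)n1CC` gives 7130 nM in this assay, and compound 3 `CCn1c(C(=O)N[C@H](CO)C(C)C)ccc1C(CC)(CC)c1ccc(OCS(=O)(=O)c2ccccc2)c(C)c1` gives 7300 nM. The steps of an at least 7.0-fold lower number from compound 1 to compound 2 (0.84 log units; beyond the scatter) and an at least 6.8-fold lower number from compound 1 to compound 3 (0.83 log units; beyond the scatter) show that replacing the group on this nitrogen can lower the number at least modestly, while a 1.0-fold higher number from compound 2 to compound 3 (0.01 log units; within the scatter) keeps compounds 2 and 3 level. Compound 4 `CCn1c(C(=O)N[C@@H](C)C(=O)O)ccc1C(CC)(CC)c1ccc(OCS(=O)(=O)c2ccccc2)c(C)c1` is not yet measured; it differs from compound 1 by 1-carboxyethyl in place of 1-(methoxycarbonyl)ethyl on an amide-type nitrogen. For the measured compounds named here, neither measured step brings in a 1-carboxyethyl group, so the direction of this change rests on no direct precedent. Compound 4 is therefore expected to stay near the limit, at about 60000 nM, between 15000 nM and 200000 nM. The expected step is estimated as a step that the limit leaves unreadable from compound 1 to compound 4.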

Compound 4, half-maximal inhibitory concentration: 16800 nM
Estimate against measurement, compound 4: 3.6-fold (0.55 log units) above, and the stated range covers the measured number.
By their numbers in this assay, from the lowest: compounds 2 and 3 (each within the scatter of the next); then compound 4. At a limit, above all of these: compound 1.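

In this assay, putting 1-carboxyethyl in place of 1-(methoxycarbonyl)ethyl on the amide-type nitrogen gives an at least 2.9-fold lower number from compound 1 to compound 4 (0.47 log units; beyond the scatter), so even this change at the end of the tail, from 6 heavy atoms to 5, moves the result beyond the scatter. The 1-carboxyethyl group still does not match the two groups measured earlier, with a 2.3-fold higher number from compound 3 to compound 4 (0.36 log units; beyond the scatter) and a 2.4-fold higher number from compound 2 to compound 4 (0.37 log units; beyond the scatter). Compound 1 has only a limit, so the full size of the step from it stays unknown: the limit of > 50000 nM in this assay, at which 1 of the 4 values shown sits.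

The compounds shown leave open whether a primary amide or an ethyl ester in this place would fall nearer compound 1 or compound 4. They also leave open how a longer chain carrying the carboxylic acid would compare with the 1-carboxyethyl group.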